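A few compounds are considered here, and "the series" means these few. Any claim that something is new, unique, unknown or untested is made for them only; others in the source may bear on it.

In an ADME assay on cells (Macrophage, Homo sapiens) for cytotoxicity, read by microscopy and MTT assay, with a stated time of 24 h (on this read-out higher numbers stand for lower toxicity in this test and lower numbers for higher toxicity in this test), compound 1 `Cc1ncc([N+](=O)[O-])n1CCOc1ccc(/C=N/Nc2nc(-c3ccccc3)cs2)cc1` reads 467 ug/mL while compound 2 `COc1ccc(-c2csc(N/N=C/c3ccc(OCCn4c([N+](=O)[O-])cnc4C)cc3)n2)cc1` reads 268 ug/mL and compound 3 `COc1ccc(-c2csc(N/N=C/c3cccc(OCCn4c([N+](=O)[O-])cnc4C)c3)n2)cc1` reads 238 ug/mL on the same scale. Compound 3 thus sits within the usual scatter of both other compounds. Moving to compound 4 `Cc1ncc([N+](=O)[O-])n1CCOc1cccc(/C=N/Nc2nc(-c3ccc(C(F)(F)F)cc3)cs2)c1` makes one structural change trifluoromethyl in place of methoxy on an aromatic carbon in which trifluoromethyl takes the place of methoxy on an aromatic carbon. Going by the values given here, the only measured step bearing on this is a 1.7-fold lower number from compound 1 to compound 2 (0.24 log units; within the scatter) and that step, methoxy in place of hydrogen on an aromatic carbon, stays within the scatter. Among the compounds with values here, no measured compound carries trifluoromethyl, so the evidence is thin. No step beyond the scatter is therefore expected in this assay here. The estimated step is a 1.1-fold higher number from compound 3 to compound 4 (0.02 log units; within the scatter) on this basis. Compound 4 is estimated at 250 ug/mL with an expected range from 120 ug/mL to 480 ug/mL in this test.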

Compound 4, half-maximal cytotoxic concentration: 517 ug/mL
For compound 4 the middle estimate is 2.1-fold (0.32 log units) below the measured one; measured number outside the range, above it.
By their numbers in this assay, from the lowest: compounds 3, 2, 1 and 4 (each within the scatter of the next, the first and the last beyond it).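

In this assay the change from 4-methoxyphenyl to 4-(trifluoromethyl)phenyl gives a 2.2-fold higher number from compound 3 to compound 4 (0.34 log units; beyond the scatter) and so shows that this place on the ring can modestly move the read-out beyond the scatter, toward lower toxicity in this test. The earlier step of a 1.7-fold lower number from compound 1 to compound 2 (0.24 log units; within the scatter) on the core of compound 1 stayed within the scatter and did not show this. Nothing available explains the new step.

As far as these compounds go, whether the same change would move the number on the core of compound 1 stays open. So does the effect of an amine or a carboxylic acid at this place.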